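Debenzylation step toward the fully deprotected diol

A few compounds are considered here, and "the series" means these few. Any claim that something is new, unique, unknown or untested is made for them only; others in the source may bear on it.

Measured so far in a functional assay on SW-620 cells (Homo sapiens) for antiproliferative activity, read by MTT assay, with a stated time of 72 h; on this read-out lower numbers stand for stronger inhibition and higher numbers for weaker inhibition:
- compound 1, `C[Si](C)(C)CCOCn1c(CC(O)(COCc2ccccc2)COCc2ccccc2)cc(=O)[nH]c1=O`: > 100000 nM
- compound 2, `C[Si](C)(C)CCOCn1c(CC(O)(CO)CO)cc(=O)[nH]c1=O`: > 100000 nM
- compound 3, `C[Si](C)(C)CCOCn1c(CC(O)COCc2ccccc2)cc(=O)[nH]c1=O`: > 100000 nM

Each of these three values is a limit of the assay, not a number. Compound 3 therefore stands only at that limit, and the same holds for compound 1 and for compound 2. Among the measured compounds shown here, the one comparable step, a step that the two limits leave unreadable from compound 1 to compound 3, cannot be read, because the limit of > 100000 nM in this assay, at which 3 of the 3 values shown sit, caps both ends.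

Compound 4, `C[Si](C)(C)CCOCn1c(CC(O)CO)cc(=O)[nH]c1=O`, differs from compound 3 by hydrogen in place of benzyl on an oxygen on a saturated carbon. No measured step bears on this change beyond the unreadable one, and all shown values sit at the limit. The expectation is therefore no step beyond the scatter, a step that the limit leaves unreadable from compound 3 to compound 4, and compound 4 is estimated at 150000 nM, within 50000 nM to 500000 nM, most likely reported again as a limit.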

Compound 4, half-maximal inhibitory concentration: > 100000 nM
Compound 4 was reported as a limit; the forecaster's own chance of this, stated with the estimate: 90%; the middle value does not contradict the limit.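

No step can be read from compound 3 to compound 4 or from compound 2 to compound 4, because both ends of each pair sit at the same limit: the limit of > 100000 nM in this assay, at which 4 of the 4 values shown sit.

Still open, as far as these compounds go, is whether hydrogen in place of benzyl changes anything in this assay.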